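From Methylsulfonyl to Dimethylcarbamoyl on a Saturated Ring Carbon

The compounds below may be only part of what the source reports. "The series", "measured", "known", "first", "only" and "open" are said of these compounds alone.

Compound 1 `CC(=O)C1(c2cc(F)cc(OCc3ccc(-n4ccnc4C)cc3)c2)CCOCC1`: 130 nM
Compound 2 `Cc1nccn1-c1ccc(COc2cc(F)cc(C3(S(C)(=O)=O)CCOCC3)c2)cc1`: > 1000 nM

In an assay on blood for inhibition of Polyunsaturated fatty acid 5-lipoxygenase (Homo sapiens) (on this read-out lower numbers stand for stronger inhibition and higher numbers for weaker inhibition), compound 1 gives 130 nM. For compound 2 the read-out is only a limit, > 1000 nM, so its standing is known only as a bound (the limit of > 1000 nM in this assay, at which 1 of the 2 values shown sits). For the measured compounds named here, the single measured step, an at least 7.6-fold higher number from compound 1 to compound 2 (0.88 log units; beyond the scatter), bears directly on the change now considered, since it concerns the same saturated ring carbon of the shared core. Compound 3 `Cc1nccn1-c1ccc(COc2cc(F)cc(C3(C(=O)N(C)C)CCOCC3)c2)cc1` differs from compound 2 by dimethylcarbamoyl in place of methylsulfonyl on a saturated ring carbon. The methylsulfonyl that cost potency leaves, and a group carrying a carbonyl, as in compound 1, enters; the step is therefore expected to run back toward stronger inhibition, though its size is uncertain because compound 2 sits at the limit of > 1000 nM in this assay, at which 1 of the 2 values shown sits. The expected step is an at least 2.5-fold lower number from compound 2 to compound 3 (0.39 log units; beyond the scatter). The number for compound 3 is estimated at 400 nM, with a range from 100 nM to 1500 nM.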

Compound 3, half-maximal inhibitory concentration: 810 nM
Estimate against measurement, compound 3: 2.0-fold (0.31 log units) below; the range from low to high includes it.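

With a 6.2-fold higher number from compound 1 to compound 3 (0.79 log units; beyond the scatter) in this assay when dimethylamino replaces methyl on the carbonyl carbon, a carbonyl on this saturated ring carbon proves not to be enough by itself to keep the inhibition seen for compound 1. Dimethylcarbamoyl in place of methylsulfonyl gives an at least 1.2-fold lower number from compound 2 to compound 3 (0.09 log units; that floor lies within the scatter) and so offers only a floor, which does not establish a recovery. Going by these compounds, the true size of that step stays unknown because compound 2 is held at a limit of the assay: the limit of > 1000 nM in this assay, at which 1 of the 3 values shown sits.

The compounds shown leave open how a primary amide, a carboxylic acid or a nitrile on this saturated ring carbon would compare with acetyl. On these data alone, it also remains open whether methylamino on the carbonyl carbon would read closer to methyl or to dimethylamino.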